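Thiazolyl to Fluoropyridinyl Ether: Plasma Free Fraction Outlook

The source may report more compounds than this note shows. Statements on the series, on what has been measured and on what is new or still open speak of the compounds shown alone.

Compound 1 `CC(C)Oc1ccc(Nc2nc(=O)n(CCCO)c(=O)n2Cc2ccc(Cl)cc2)cc1Cl`: 0.003
Compound 2 `C[C@@H](Cn1c(=O)[nH]/c(=N\c2ccc(Oc3nccs3)cc2)n(Cc2ccc(Cl)cc2)c1=O)C(=O)O`: 0.006
Compound 3 `CC(C)Oc1ccc(/N=c2\[nH]c(=O)n(C[C@@H](C)C(=O)O)c(=O)n2Cc2ccc(Cl)cc2)cc1Cl`: 0.002

These three compounds have been measured in an ADME assay on the whole organism (plasma, Rattus norvegicus) for protein binding, using cassette dosing, at a dose of 1 mg/kg; on this read-out lower numbers stand for a smaller free fraction and higher numbers for a larger free fraction. Compound 2 stands at the top of the three numbers, although compound 1 lies within the scatter of it; only compound 3 sits beyond the scatter, on the lower side. Compound 4 `C[C@@H](Cn1c(=O)[nH]/c(=N\c2ccc(Oc3cncc(F)c3)cc2)n(Cc2ccc(Cl)cc2)c1=O)C(=O)O` has not yet been measured. It differs from compound 2 by 5-fluoropyridin-3-yl in place of 1,3-thiazol-2-yl on an oxygen on an aromatic ring. Going by the values given here, no step between measured compounds isolates such a change, so the expectation rests on compound 2 alone. The step is expected to be small, no change at the digits printed from compound 2 to compound 4 (within the scatter), with nothing beyond the scatter foreseen in either direction. Compound 4 is therefore estimated at 0.006, with a range from 0.003 to 0.012.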

Compound 4, unbound fraction: 0.02
Beside the measured number, compound 4's estimate is 3.3-fold (0.52 log units) below it; measured number outside the range, above it.
By their numbers in this assay, from the lowest: compounds 3, 1 and 2 (each within the scatter of the next, the first and the last beyond it); then compound 4.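

In this assay, the group on this oxygen turns out to matter for the free fraction: 5-fluoropyridin-3-yl in place of 1,3-thiazol-2-yl gives a 3.3-fold higher number from compound 2 to compound 4 (0.52 log units; beyond the scatter). Going by these compounds alone, the earlier compounds offered no step that isolated any change at this position, so this is the first reading of it, with the rest of the structure held constant. Nothing at hand gives a reason for the step.

From the compounds shown here alone, whether a pyridin-3-yl without the fluorine, or a plain phenyl on the same oxygen, would give the same step remains open. Also open, going by these compounds, is whether the change holds with an amide in place of the carboxylic acid.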